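The source may report more compounds than this note shows. Statements on the series, on what has been measured and on what is new or still open speak of the compounds shown alone.

Compound 1 `CCOC(=O)C1CCN(C(=O)CN2CN(c3ccccc3)C3(CCN(C(=O)c4ccc(C5CCCCC5)cc4)CC3)C2=O)CC1` gives 900 nM in an assay on HEK293 cells for displacement of a labelled ligand from NPC1-like intracellular cholesterol transporter 1 (Homo sapiens); on this read-out lower numbers stand for stronger inhibition and higher numbers for weaker inhibition. Compound 2 `CCOC(=O)C1CCN(C(=O)CN2CN(c3ccccc3)C3(CCN(C(=O)c4ccc(C(C)(C)C)cc4)CC3)C2=O)CC1` is its tert-butyl analogue; in this assay compound 2 gives 3100 nM, the second highest of the three numbers, while compound 3 `CC(C)(C)c1ccc(C(=O)N2CCC3(CC2)C(=O)N(CC(=O)NCCCCO)CN3c2ccccc2)cc1` gives 19200 nM. The two measured steps are a 3.4-fold higher number from compound 1 to compound 2 (0.54 log units; beyond the scatter) and a 6.2-fold higher number from compound 2 to compound 3 (0.79 log units; beyond the scatter), each a modest loss. Compound 4 `CCc1nn(CC)c(C2CCN(C(=O)CN3CN(c4ccccc4)C4(CCN(C(=O)c5ccc(C(C)(C)C)cc5)CC4)C3=O)CC2)c1CC` differs from compound 2 in one place: 1,3,4-triethyl-1H-pyrazol-5-yl in place of ethoxycarbonyl on a saturated ring carbon. Among the compounds with values here, only the step from compound 2 to compound 3 concerns the same end of the molecule, and there the whole 4-(ethoxycarbonyl)piperidin-1-yl group was replaced rather than the group on the six-membered non-aromatic ring exchanged, so it gives limited guidance; no step beyond the scatter is expected in either direction. Compound 4 is therefore estimated at 3000 nM, within 1000 nM to 10000 nM, a step of a 1.0-fold lower number from compound 2 to compound 4 (0.01 log units; within the scatter).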

Compound 4, half-maximal inhibitory concentration: 4600 nM
For compound 4 the middle estimate is 1.5-fold (0.19 log units) below the measured one, within the range that was stated.
By their numbers in this assay, from the lowest: compound 1; then compounds 2 and 4 (each within the scatter of the next); then compound 3.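

On a saturated ring carbon of the six-membered ring, exchanging ethoxycarbonyl for 1,3,4-triethyl-1H-pyrazol-5-yl gives a 1.5-fold higher number from compound 2 to compound 4 (0.17 log units; within the scatter) in this assay. So at this position, an aromatic ring with 11 heavy atoms can stand in for a group of 5 without a change beyond the scatter, which the earlier step, replacing the whole piperidine group, could not show. Nothing available here explains this result. Still open, from the compounds shown here alone, is how a carboxylic acid, an amine or a simple phenyl ring at this ring carbon would read.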